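Adding a Trifluoromethyl Group to a Fluorophenyl Urea

A few compounds are considered here, and "the series" means these few. Any claim that something is new, unique, unknown or untested is made for them only; others in the source may bear on it.

Measured so far:
compound 1, `C[C@H](NC(=O)Nc1ccccc1F)c1ccccc1`, gives 92%
compound 2, `C[C@H](NC(=O)Nc1ccc(F)cc1F)c1ccccc1`, gives 100%
compound 3, `Cc1ccc(NC(=O)N[C@@H](C)c2ccccc2)c(F)c1`, gives 99%

All three compounds were tested in an ADME assay on the whole organism with Oryza sativa as the target, tested at 1 uM; a higher number here means a weaker effect of the compound at the concentration tested, a lower number a stronger effect. Compound 1 has the lowest of the three numbers, but the gaps to the other two are small: a number 8 percentage points higher from compound 1 to compound 2 (within the scatter) and a number 7 percentage points higher from compound 1 to compound 3 (within the scatter), both within the scatter, so the three compounds cannot be told apart on these readings. The step of a number 1 percentage points lower from compound 2 to compound 3 (within the scatter) is likewise within the scatter.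

Compound 4, `C[C@H](NC(=O)Nc1cccc(C(F)(F)F)c1F)c1ccccc1`, has not yet been measured. It differs from compound 1 in one place: trifluoromethyl in place of hydrogen on an aromatic carbon.

Among the compounds with values here, two measured steps bear on this change, since each also places a single new group on an aromatic carbon of the same ring of compound 1: fluoro in place of hydrogen, giving a number 8 percentage points higher from compound 1 to compound 2 (within the scatter), and methyl in place of hydrogen, giving a number 7 percentage points higher from compound 1 to compound 3 (within the scatter). Neither moved the number beyond the scatter. Trifluoromethyl in place of hydrogen is a different group, so this is only a guide, but on these data no step beyond the scatter is expected in this assay, in either direction.

Compound 4 is therefore expected to give about 96%, within the range 86% to 104%, which means an expected step of a number 4 percentage points higher from compound 1 to compound 4 (within the scatter).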

Compound 4, a percentage reported as activity, at one concentration (the size of the read-out at that concentration, not a potency): 98%
Estimate against measurement, compound 4: 2 percentage points below, and the stated range covers the measured number.
By their numbers in this assay, from the lowest: compounds 1, 4, 3 and 2 (each within the scatter of the next).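

In this assay, trifluoromethyl, a group of 4 heavy atoms with no ring and no net charge, replaces a hydrogen on an aromatic carbon ortho to a fluoro group, and this gives a number 6 percentage points higher from compound 1 to compound 4 (within the scatter), so a substituent of this size at this carbon produces no step beyond the scatter. Within the data shown here, the earlier steps covered only fluoro and methyl, and neither of those groups sat ortho to a fluoro group, so this is the first reading for this carbon and for this group. No measurement is available that could explain why the reading behaves this way.

What the compounds shown leave open is whether any group at this carbon can move the number beyond the scatter, for instance an amine, a carboxylic acid or a longer chain such as butyl, each of which differs from trifluoromethyl in kind or in length. Also open is whether trifluoromethyl would read the same with hydrogen in place of the neighbouring fluoro group, since that pair of compounds is not among those shown here.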